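Nitro for fluoro on the aniline ring: compound 4

This account rests on a few compounds, and the source may have more. Where it says the series, first, only, none or still open, it means among the compounds named here.

Measured members of the series:
Compound 1 `CCOC(=O)C1=C(Nc2ccccc2)S/C(=C\c2ccc(O)c(O)c2)C1=O` gives 5200 nM in a functional assay on K562 cells (Homo sapiens) for inhibition, read by MTT assay, with a stated time of 72 h; a higher number here means a weaker inhibitor, a lower number a stronger inhibitor.
Compound 2 `CCOC(=O)C1=C(Nc2ccccc2)S/C(=C\c2ccc[nH]2)C1=O` gives 71000 nM in this assay.
Compound 3 `CCOC(=O)C1=C(Nc2cccc(F)c2)S/C(=C\c2ccc[nH]2)C1=O` gives > 100000 nM in this assay, which is a limit of the assay and not a number.

Compound 3 thus stands at the weak end of what the assay resolves (the limit of > 100000 nM in this assay, at which 1 of the 3 values shown sits). The measured steps differ in size: a 14-fold higher number from compound 1 to compound 2 (1.14 log units; beyond the scatter), whereas an at least 1.4-fold higher number from compound 2 to compound 3 (0.14 log units; that floor lies within the scatter). Compound 4 `CCOC(=O)C1=C(Nc2cccc([N+](=O)[O-])c2)S/C(=C\c2ccc[nH]2)C1=O` differs from compound 3 by nitro in place of fluoro on an aromatic carbon. For the measured compounds named here, no measured step exchanges one substituent for another on that ring; the only change there, fluoro for hydrogen, gave a floor within the scatter. A step in this assay beyond the scatter is therefore not expected: the estimated step is a number no higher from compound 3 to compound 4 (the limit leaves the size open). Compound 4 is expected at 100000 nM, in the range 30000 nM to 300000 nM, most likely again reported only as a limit.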

Compound 4, half-maximal inhibitory concentration: 7200 nM
Compound 4: middle estimate off by 14-fold (1.14 log units), on the high side; measured number outside the range, below it.
By their numbers in this assay, from the lowest: compounds 1 and 4 (each within the scatter of the next); then compound 2. At a limit, above all of these: compound 3.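

This aromatic carbon is not silent in this assay: nitro in place of hydrogen gives a 9.9-fold lower number from compound 2 to compound 4 (0.99 log units; beyond the scatter), whereas fluoro in place of hydrogen gave only a floor within the scatter. Exchanging the two substituents gives an at least 13-fold lower number from compound 3 to compound 4 (1.14 log units; beyond the scatter), so the outcome here depends on which group is present. The value of compound 3 is a limit of the assay and not a number, so this step is a floor: the limit of > 100000 nM in this assay, at which 1 of the 4 values shown sits.

On these data alone, whether an amine or a carboxylic acid on this carbon would behave like nitro remains open. Also open, as far as these compounds go, is whether nitro gives a similar step when 3,4-dihydroxyphenyl replaces 1H-pyrrol-2-yl.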